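A few compounds are considered here, and "the series" means these few. Any claim that something is new, unique, unknown or untested is made for them only; others in the source may bear on it.

Notes on the series. Compound 1 `COCC1CN(S(=O)(=O)c2ccc(F)cc2)CCN1C(C)=O` carries a methoxymethyl group on a saturated ring carbon of the shared core. In an ADME assay on a cell-free system (plasma, Rattus norvegicus, strain Sprague-Dawley) for metabolic stability, read by LC-MS, tested at 1 uM (a higher number here means that the compound lasts longer, a lower number that the compound disappears faster), compound 1 gives >= 4 h, which is a limit of the assay and not a number. Compound 2 `CC(=O)N1CCN(S(=O)(=O)c2ccc(F)cc2)CC1` has hydrogen in that place. In this assay compound 2 gives >= 4 h, again a limit. The step that the two limits leave unreadable from compound 1 to compound 2 is therefore not readable. Compound 3 `CC(=O)OCC1CN(C(C)=O)CCN1S(=O)(=O)c1ccc(F)cc1` carries acetoxymethyl on a saturated ring carbon. In this assay, among the compounds with values here, compound 3 gives 0.483 h, the only true number among the three values shown. The other two sit at the limit of >= 4 h in this assay, at which 2 of the 3 values shown sit. Within the data shown here, the step of an at least 8.2-fold lower number from compound 2 to compound 3 (0.91 log units; beyond the scatter) is thus the one measured step with a readable size, and compound 3 stands alone as the shortest-lived of the set.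

Compound 4 `CC(=O)N1CCN(S(=O)(=O)c2ccc(F)cc2)C(CO)C1` differs from compound 3 by hydrogen in place of acetyl on an oxygen on a saturated carbon; cut one bond further out, the change reads acetoxymethyl to hydroxymethyl. The step of an at least 8.2-fold lower number from compound 2 to compound 3 (0.91 log units; beyond the scatter) bears on it most directly: it introduced the acetoxymethyl whose acetyl now leaves. Compound 1, with methoxymethyl on the same kind of carbon, also sits at the limit. An increase in this assay is expected, of about an 8.3-fold higher number from compound 3 to compound 4 (0.92 log units; beyond the scatter), the open question being whether compound 4 reaches the limit. Compound 4 is estimated at 4 h in this assay, within a range from 1.5 h to 8 h.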

Compound 4, half-life in the plasma assay: >= 4 h
Compound 4: no number, only a limit; the forecaster's own chance of this, stated with the estimate: 60%; the middle value lies on the limit itself.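

In the plasma assay, replacing acetyl with hydrogen on the oxygen gives an at least 8.2-fold higher number from compound 3 to compound 4 (0.91 log units; beyond the scatter), so among the compounds shown the short half-life belongs to the acetoxymethyl compound alone, while hydroxymethyl, like methoxymethyl and hydrogen on the saturated ring carbon, leaves the value at the limit. Within the data shown here, in a physicochemical assay for metabolic stability, read by LC-MS, in phosphate buffer, tested at 1 uM (a higher number here means that the compound lasts longer, a lower number that the compound disappears faster), compound 3 gives >= 4 h, a limit of the assay and not a number, so the rapid disappearance of compound 3 in the plasma assay has no counterpart in buffer. In the physicochemical assay compound 4 gives >= 4 h, also a limit, and the steps with limits at both ends cannot be read.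

Any order among compound 1, compound 2 and compound 4 in the plasma assay stays open, because all three stop at the same limit: the limit of >= 4 h in the plasma assay, at which 3 of the 4 values shown sit. Whether a longer acyl chain in place of acetyl, or an amine on the saturated ring carbon in place of acetoxymethyl, would shorten the half-life in the plasma assay also stays open, and the values in the physicochemical assay show no spread among the compounds shown: the limit of >= 4 h in the physicochemical assay, at which 2 of the 2 values shown sit.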